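The compounds below may be only part of what the source reports. "The series", "measured", "known", "first", "only" and "open" are said of these compounds alone.

All four compounds share one core carrying a benzene ring with a sulfonyl group, and they differ only in the amine attached to that sulfonyl sulfur. Compound 3 `CCCn1c(=O)[nH]c2nc(-c3ccc(S(=O)(=O)N(C)C)cc3)[nH]c2c1=O` bears a dimethylamino group there. In an assay on CHO cells for displacement of a labelled ligand from adenosine receptor A1 (Homo sapiens), read by scintillation counting, with a stated time of 90 min, in the presence of a further agent that is not named here (a higher number here means a weaker inhibitor, a lower number a stronger inhibitor), compound 3 gives 190 nM, the lowest number among those measured. Compound 2 `CCCn1c(=O)[nH]c2nc(-c3ccc(S(=O)(=O)N4CCN(Cc5cccc(C)c5)CC4)cc3)[nH]c2c1=O`, whose piperazine carries a 3-methylbenzyl group, gives 795 nM in this assay. Compound 1 `CCCn1c(=O)[nH]c2nc(-c3ccc(S(=O)(=O)N4CCN(c5ccc(F)cc5)CC4)cc3)[nH]c2c1=O`, whose piperazine carries a 4-fluorophenyl group, reaches only a limit of this assay, namely > 1000 nM. The step of an at least 1.2-fold lower number from compound 1 to compound 2 (0.09 log units; that floor lies within the scatter) can be stated only as a floor because the limit of > 1000 nM in this assay, at which 1 of the 3 values shown sits, hides the true number of compound 1.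

Compound 4 `CCCn1c(=O)[nH]c2nc(-c3ccc(S(=O)(=O)N4CCN(C)CC4)cc3)[nH]c2c1=O` has not yet been measured. The change is 4-methylpiperazin-1-yl in place of dimethylamino on a sulfonyl sulfur. Among the compounds with values here, no measured step makes exactly this exchange: the step from compound 1 to compound 2 alters the group on the far piperazine nitrogen, not the amine on the sulfur. The values of compound 2 and compound 3 show a piperazine sulfonamide beside a dimethyl sulfonamide, with the higher number for the ring.

For compound 4 the step of a 2.1-fold higher number from compound 3 to compound 4 (0.32 log units; beyond the scatter) is therefore expected to go toward a higher number. The estimate for compound 4 in this assay is 400 nM, within a range from 150 nM to 1200 nM.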

Compound 4, inhibition constant: 334 nM
Beside the measured number, compound 4's estimate is 1.2-fold (0.08 log units) above it; low and high end bracket the measured number.
By their numbers in this assay, from the lowest: compounds 3 and 4 (each within the scatter of the next); then compound 2. At a limit, above all of these: compound 1.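

In this assay, the step for 4-methylpiperazin-1-yl in place of dimethylamino on a sulfonyl sulfur is a 1.8-fold higher number from compound 3 to compound 4 (0.24 log units; within the scatter) and so shows that this position accepts the ring with no change that can be told from the scatter, something the earlier ring compounds, with their larger aryl-bearing groups, could not show. The higher number of compound 2 therefore does not come with the ring alone, since the group on the ring's amine nitrogen also counts: hydrogen in place of 3-methylphenyl on a saturated chain carbon bound to that nitrogen gives a 2.4-fold lower number from compound 2 to compound 4 (0.38 log units; beyond the scatter) as a modest gain. Methyl in place of 4-fluorophenyl on an amine nitrogen in a ring gives an at least 2.9-fold lower number from compound 1 to compound 4 (0.47 log units; beyond the scatter) and this step can be read only as a floor: the limit of > 1000 nM in this assay, at which 1 of the 4 values shown sits.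

From the compounds shown here alone, how a piperazine with only hydrogen on that nitrogen, or with an ethyl group or a longer chain there, would compare with these compounds stays open. So does whether a morpholine ring or a diethylamino group on the sulfonyl sulfur would read like dimethylamino.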